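A methoxy group moved to a second aromatic position

This account rests on a few compounds, and the source may have more. Where it says the series, first, only, none or still open, it means among the compounds named here.

Compound 1 `O=C1CC(c2ccccc2)=NCC2(CN3CCC2CC3)N1` is the parent of this small set. Among the measured compounds shown here, in an assay on cell membranes for displacement of a labelled ligand from Neuronal acetylcholine receptor; alpha4/beta2 (Rattus norvegicus), read by scintillation counting, with a stated time of 2 h, tested at 5 uM (on this read-out higher numbers stand for more inhibition at the one concentration tested (going by the name of the read-out) and lower numbers for less inhibition), compound 1 gives 15%, the highest of the two numbers measured so far, though its nearest neighbour, compound 2 `COc1ccccc1C1=NCC2(CN3CCC2CC3)NC(=O)C1`, gives 7% in this assay, and the difference between them lies within the scatter. For the measured compounds named here, the one step available, a number 8 percentage points lower from compound 1 to compound 2 (within the scatter), therefore tells of no real change on adding a methoxy at that aromatic carbon. Compound 3 `COc1cccc(C2=NCC3(CN4CCC3CC4)NC(=O)C2)c1` carries the same change at another place: methoxy in place of hydrogen on an aromatic carbon, meta to a large group. Going by the values given here, the only step that bears on it is the one from compound 1 to compound 2, which stayed within the scatter, so in this assay no step beyond the scatter is expected for compound 3 either, and the expectation is a number 4 percentage points lower from compound 1 to compound 3 (within the scatter). Compound 3 is estimated at 11%, with a range from 0% to 25%.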

Compound 3, a percentage reported as inhibition, at one concentration (the size of the read-out at that concentration, not a potency): 12%
Beside the measured number, compound 3's estimate is 1 percentage points below it; low and high end bracket the measured number.
By their numbers in this assay, from the lowest: compounds 2, 3 and 1 (each within the scatter of the next).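

In this assay the change now reads as a number 3 percentage points lower from compound 1 to compound 3 (within the scatter), so methoxy in place of hydrogen on an aromatic carbon, meta to a large group, gives no step beyond the scatter. The same change has now been read at a second place on the ring and has again produced no step beyond the scatter, which gives no ground for ranking the two places against each other. Nothing available here offers an account of this result.

Going by these compounds, it remains open whether a different group at this place, such as an amine, a carboxylic acid or a longer chain, would give a step beyond the scatter. Also open, on these data alone, is whether compounds this close at one concentration would stay close in a full measure of potency.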